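A few compounds are considered here, and "the series" means these few. Any claim that something is new, unique, unknown or untested is made for them only; others in the source may bear on it.

Measured compounds:
Compound 1, `Cc1ccc(NC(=O)c2cccc(N(C)C)c2)cc1NC(=O)c1ccc(OC(C)C)cc1`. In an ADME assay on a cell-free system (plasma, Homo sapiens) for protein binding (a higher number here means a larger unbound share of the compound, a lower number a smaller unbound share), compound 1 gives < 0.01, which is a limit of the assay and not a number.
Compound 2, `Cc1ccc(-c2c[nH]cn2)cc1NC(=O)c1ccc(OCc2ccccn2)cc1`. In this assay compound 2 gives 0.051.

For the measured compounds named here, compound 2 thus holds the only numerical value in this set; the other entry sits at the limit of < 0.01 in this assay, at which 1 of the 2 values shown sits, so no measured step between the two can be stated, and the pair shows only that compound 2 is the one with a readable unbound fraction.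

Compound 3, `Cc1ccc(-c2nccn2C)cc1NC(=O)c1ccc(OCc2ccccn2)cc1`, is not yet measured. It differs from compound 2 by 1-methyl-1H-imidazol-2-yl in place of 1H-imidazol-4-yl on an aromatic carbon. Going by the values given here, with no measured step of this kind available, the expectation for this assay is a step of a 1.5-fold lower number from compound 2 to compound 3 (0.16 log units; within the scatter), a modest move toward a smaller unbound share, close to the usual scatter rather than clearly beyond it. Compound 3 is estimated at 0.035, with a range from 0.014 to 0.09.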

Compound 3, unbound fraction: 0.051
Beside the measured number, compound 3's estimate is 1.5-fold (0.16 log units) below it; low and high end bracket the measured number.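

For the compounds shown here, the first step that can be read in this assay is no change at the digits printed from compound 2 to compound 3 (within the scatter), with 1-methyl-1H-imidazol-2-yl in place of 1H-imidazol-4-yl on an aromatic carbon. At this position, then, a five-membered aromatic ring with 0 hydrogen-bond donors stands in for one with 1 hydrogen-bond donor, and the unbound fraction does not move beyond the scatter. Nothing at hand gives a reason for this result.

Going by these compounds alone, compound 1 gives < 0.01, which is a limit of the assay and not a number, and no step to it can be read. On these data alone, whether this position stays as undemanding with an amine or a carboxylic acid in place of the imidazole ring remains open, as does what the methyl group on the ring contributes on its own.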